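From Oxime to Hydroxymethyl: An Untested Step

The compounds below may be only part of what the source reports. "The series", "measured", "known", "first", "only" and "open" are said of these compounds alone.

Compound 1 `CCCCOCc1cn(-c2cc(Cl)ccc2Cl)nn1`: 317 nM
Compound 2 `O/N=C/c1cnn(-c2ccccc2)n1`: 349 nM

Both were measured in an assay on isolated protein (strain Swiss) for antagonist activity at P2X purinoceptor 7 (Mus musculus), read by flow cytometry and propidium iodide staining, with a stated time of 25 min; on this read-out higher numbers stand for weaker inhibition and lower numbers for stronger inhibition. Compound 2 gives 349 nM, the higher of the two numbers, but its gap to compound 1 lies within the scatter, so the two cannot be told apart. Compound 3 `OCc1cnn(-c2ccccc2)n1` has not been measured. It differs from compound 2 by a group of 2 heavy atoms (1 carbon, 1 oxygen; no ring) in place of a group of 3 heavy atoms (1 carbon, 1 nitrogen, 1 oxygen; no ring), on an aromatic carbon. For the measured compounds named here, no measured pair shows this change, so its size is unknown; only a small step in this assay is expected, if any beyond the scatter, toward a higher number. Compound 3 is estimated at 500 nM, with a range from 150 nM to 1700 nM. The expected step is a 1.4-fold higher number from compound 2 to compound 3 (0.16 log units; within the scatter).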

Compound 3, half-maximal inhibitory concentration: 96 nM
Estimate against measurement, compound 3: 5.2-fold (0.72 log units) above; measured number outside the range, below it.
By their numbers in this assay, from the lowest: compound 3; then compounds 1 and 2 (each within the scatter of the next).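

In this assay, putting hydroxymethyl in place of the group of compound 2 on this aromatic carbon gives a 3.6-fold lower number from compound 2 to compound 3 (0.56 log units; beyond the scatter), so this position responds measurably to a small change. The change removes the double bond outside the ring and one hydrogen-bond acceptor, while both groups keep one hydrogen-bond donor. Nothing measured here accounts for the step. As far as these compounds go, how an amine, a carboxylic acid or a longer chain would fare on this carbon remains open. So does whether the hydrogen-bond donor is needed at all.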